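From 4-bromophenyl to 3,4-dimethoxyphenyl: an unmeasured step

The source may report more compounds than this note shows. Statements on the series, on what has been measured and on what is new or still open speak of the compounds shown alone.

Compound 1 `CC(C)(C)n1cc2c(n1)C(=O)CC1(CCN(C(=O)c3cc(-c4ccccc4)nc4ccccc34)CC1)O2`: 2110 nM
Compound 2 `Cc1ccc(-c2cc(C(=O)N3CCC4(CC3)CC(=O)c3nn(C(C)(C)C)cc3O4)c3ccccc3n2)cc1`: 1440 nM
Compound 3 `CC(C)(C)n1cc2c(n1)C(=O)CC1(CCN(C(=O)c3cc(-c4ccc(Br)cc4)nc4ccccc34)CC1)O2`: 820 nM

All three values come from a functional assay on HepG2 cells (Homo sapiens) for inhibition, read by MTT assay, with a stated time of 72 h; on this read-out higher numbers stand for weaker inhibition and lower numbers for stronger inhibition. Compound 3 stands apart from only one of the other two. The data show a 2.6-fold lower number from compound 1 to compound 3 (0.41 log units; beyond the scatter), but only a 1.8-fold lower number from compound 2 to compound 3 (0.24 log units; within the scatter). Compound 4 `COc1ccc(-c2cc(C(=O)N3CCC4(CC3)CC(=O)c3nn(C(C)(C)C)cc3O4)c3ccccc3n2)cc1OC` carries 3,4-dimethoxyphenyl in place of 4-bromophenyl on an aromatic carbon. For the measured compounds named here, no measured compound carries this group, so no measured step covers the change directly. The nearest guide is the set of steps among the three phenyl variants. Besides the two above, these include a 1.5-fold lower number from compound 1 to compound 2 (0.17 log units; within the scatter). Replacing the bromo group has so far cost little, and the steps remain small. A small move to a higher number in this assay is therefore expected, probably not clearly beyond the scatter. The expected step is a 1.6-fold higher number from compound 3 to compound 4 (0.20 log units; within the scatter). Compound 4 is estimated at 1300 nM, with an expected range from 500 nM to 3400 nM.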

Compound 4, half-maximal inhibitory concentration: 1560 nM
The estimate for compound 4 lay 1.2-fold (0.08 log units) below the measured number; the range from low to high includes it.
By their numbers in this assay, from the lowest: compounds 3, 2, 4 and 1 (each within the scatter of the next, the first and the last beyond it).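

In this assay, replacing 4-bromophenyl with 3,4-dimethoxyphenyl at this position, next to the ring nitrogen, stays within the scatter (a 1.9-fold higher number from compound 3 to compound 4 (0.28 log units; within the scatter)). The same holds when 3,4-dimethoxyphenyl replaces 4-methylphenyl (a 1.1-fold higher number from compound 2 to compound 4 (0.03 log units; within the scatter)) or phenyl (a 1.4-fold lower number from compound 1 to compound 4 (0.13 log units; within the scatter)), so this group, unlike the bromo group in compound 3, does not separate from the unsubstituted phenyl of compound 1, and the step from compound 1 to compound 3 remains the only one here beyond the scatter (a 2.6-fold lower number from compound 1 to compound 3 (0.41 log units; beyond the scatter)). No measurement given here explains these small differences.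

The compounds shown leave open whether a single methoxy group at either ring position would behave like the pair in compound 4. They also leave open whether an amine or a carboxylic acid on this phenyl ring would move the number beyond the scatter.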